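This account rests on a few compounds, and the source may have more. Where it says the series, first, only, none or still open, it means among the compounds named here.

In a functional assay on SK-BR-3 cells (Homo sapiens) for cytotoxicity, read by MTT assay, with a stated time of 72 h (a higher number here means a weaker inhibitor, a lower number a stronger inhibitor), the series so far reads as follows:
compound 1 `N[C@H]1CC[C@H](Nc2c(C(=O)NCc3ccc(F)cc3)nc(N3CCCCS3(=O)=O)c3cccnc23)CC1` gives 8500 nM
compound 2 `COc1cccc(CNC(=O)c2nc(Br)c3cccnc3c2N[C@H]2CC[C@H](N)CC2)c1` gives 6000 nM

Compound 2 (6000 nM) stands within the scatter of compound 1 (8500 nM), so the two values cannot be told apart and neither sets a trend.

The next entry is compound 3 `N[C@H]1CC[C@H](Nc2c(C(=O)NCc3ccc(F)cc3)nc(Br)c3cccnc23)CC1`, reached from compound 2 by 4-fluorophenyl in place of 3-methoxyphenyl on a saturated chain carbon bound to an amide-type nitrogen. Among the compounds with values here, no measured pair isolates this change, so the data offer no direct step size. With compound 2 at 6000 nM as the anchor, no shift beyond the scatter is expected in this assay, and no direction is favoured with confidence. The expected change is a 1.2-fold lower number from compound 2 to compound 3 (0.08 log units; within the scatter), which stays within that scatter. For compound 3 the estimated value is 5000 nM, with an expected range of 2000 nM to 12000 nM.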

Compound 3, half-maximal inhibitory concentration: 2000 nM
Compound 3: middle estimate off by 2.5-fold (0.40 log units), on the high side, and the stated range covers the measured number.
By their numbers in this assay, from the lowest: compound 3; then compounds 2 and 1 (each within the scatter of the next).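

In this assay, 4-fluorophenyl in place of 3-methoxyphenyl on a saturated chain carbon bound to an amide-type nitrogen gives a 3.0-fold lower number from compound 2 to compound 3 (0.48 log units; beyond the scatter) as the change at this place. The second single-place comparison, one bromine atom in place of the group of 8 heavy atoms on an aromatic carbon, gives a 4.3-fold lower number from compound 1 to compound 3 (0.63 log units; beyond the scatter) with the 4-fluorobenzyl group held constant. Both places therefore register in this assay, though no measured property on hand accounts for either step.

Going by these compounds, whether the first step follows the arrival of the fluorine or the departure of the methoxy stays open, and an unsubstituted benzyl group at that place would separate the two. On these data alone, it also remains open how the aromatic carbon responds to an amine or to chlorine in place of the bromine.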